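The source may hold more compounds than are shown below. What is called first, only, known or untested is meant among the compounds shown, and "the series" means these compounds.

Working notes on the thiadiazole glycoside series. Compound 1 `CCCCCCCCCCCCCC(=O)Nc1nnc(S[C@@H]2O[C@H](COC(C)=O)[C@H](OC(C)=O)[C@H](OC(C)=O)[C@H]2OC(C)=O)s1` carries the acetylated sugar and the longer saturated acyl chain; in an ADME assay on CHO-K1 cells (Cricetulus griseus) for cytotoxicity, read by MTT assay, with a stated time of 24 h (on this read-out lower numbers stand for stronger inhibition and higher numbers for weaker inhibition), compound 1 gives 16300 nM. Compound 2 `CCCCCCCCCC(=O)Nc1nnc(S[C@@H]2O[C@H](CO)[C@H](O)[C@H](O)[C@H]2O)s1` carries the free sugar and the shorter acyl chain; in this assay compound 2 is reported as "not active" (no number reported), so no number is available for it, and its standing on this read-out cannot be fixed beyond that. Compound 3 `CCCCCCCC/C=C\CCCCCCCC(=O)Nc1nnc(S[C@@H]2O[C@H](CO)[C@H](O)[C@H](O)[C@H]2O)s1` is the unmeasured member: relative to compound 2 the change is dec-1-en-1-yl in place of ethyl on a saturated chain carbon, seven bonds along the chain from a carbonyl carbon. For the measured compounds named here, no measured pair shows what such a chain extension does here, so the size and direction of the step in this assay cannot be drawn from the data; a move toward measurable but weak inhibition is expected, with a real chance that only a limit is returned. For compound 3 in this assay the estimated value is 30000 nM, within a range of 8000 nM to 100000 nM.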

Compound 3, half-maximal inhibitory concentration: "not active" (no number reported)
Nothing numeric was reported for compound 3; no gap can be computed for the estimate.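

In this assay compound 2 and compound 3 are both reported as "not active" with no number, so no new step can be read between them. The compounds shown leave open whether ethyl to dec-1-en-1-yl changes this read-out at all. No supporting evidence bears on this result.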